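Shortening the amide chain on a weak growth inhibitor

This account rests on a few compounds, and the source may have more. Where it says the series, first, only, none or still open, it means among the compounds named here.

Compound 1 `CN1CCN(C(=O)c2c(NC(=O)NS(=O)(=O)c3ccccc3)sc3c2CCCCC3)CC1`: in a functional assay on cells (Cancer cell lines, Homo sapiens) for inhibition, with a stated time of 48 h (a higher number here means a weaker inhibitor of growth, a lower number a stronger inhibitor of growth), compound 1 gives 31300 nM.
Compound 2 `CCCCNC(=O)c1c(NC(=O)NS(=O)(=O)c2ccccc2)sc2c1CCCCC2`: in this assay compound 2 gives > 100000 nM, which is a limit of the assay rather than a number.

Compound 2 thus stands at the weak end of the two values shown, sitting at the limit of > 100000 nM in this assay, at which 1 of the 2 values shown sits. Compound 3 `CCCNC(=O)c1c(NC(=O)NS(=O)(=O)c2ccccc2)sc2c1CCCCC2` differs from compound 2 by hydrogen in place of methyl on a saturated chain carbon, three bonds along the chain from an amide-type nitrogen. Within the data shown here, the only measured step, an at least 3.1-fold higher number from compound 1 to compound 2 (0.50 log units; beyond the scatter), concerns a different change on the same carbonyl and ends in a limit, so it offers no guide to the size of this shortening. With compound 2 at a limit, compound 3 is expected to remain a weak inhibitor, with an expected step of a number no higher from compound 2 to compound 3 (the limit leaves the size open) lying within the scatter. Compound 3 is therefore estimated at 100000 nM, between 40000 nM and 300000 nM.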

Compound 3, concentration for 50% growth inhibition: 76500 nM
Compound 3: middle estimate off by 1.3-fold (0.12 log units), on the high side; the range from low to high includes it.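

In this assay compound 3 gives 76500 nM, so a propyl chain on this amide yields a true number. Set against the 4-methylpiperazin-1-yl amide, this gives a 2.4-fold higher number from compound 1 to compound 3 (0.39 log units; beyond the scatter), a measured gap that keeps the piperazine compound ahead. Removing the methyl gives an at least 1.3-fold lower number from compound 2 to compound 3 (0.11 log units; that floor lies within the scatter), and the real size of this step cannot be read because compound 2 stands at a limit: the limit of > 100000 nM in this assay, at which 1 of the 3 values shown sits.

Going by these compounds, whether a still shorter ethyl chain would bring the number any closer to that of compound 1 remains open. So does the effect of an amine at the end of the propyl chain.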